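The compounds below may be only part of what the source reports. "The series", "measured", "known", "first", "only" and "open" are said of these compounds alone.

In a functional assay on MCF7 cells (Homo sapiens) for antiproliferative activity, read by MTT assay, with a stated time of 72 h (on this read-out higher numbers stand for weaker inhibition and lower numbers for stronger inhibition), the measured compounds are:

Compound 1 `COc1cccc(N2C(=O)COc3ccc(-c4cnc(Cl)c(NS(=O)(=O)c5ccc(F)cc5)c4)cc32)c1`: > 40000 nM, a limit and not a number
Compound 2 `O=C1COc2ccc(-c3cnc(Cl)c(NS(=O)(=O)c4ccc(F)cc4)c3)cc2N1C1CCCCC1`: > 40000 nM, a limit and not a number
Compound 3 `O=C1COc2ccc(-c3cccc(NS(=O)(=O)c4ccc(F)cc4)c3)cc2N1`: 18300 nM

Going by the values given here, compound 3 holds the only true number here, at 18300 nM. The rest of the picture is the limit of > 40000 nM in this assay, at which 2 of the 3 values shown sit.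

The next compound to be tested is compound 4 `COc1cccc(N2C(=O)COc3ccc(-c4cccc(NS(=O)(=O)c5ccc(F)cc5)c4)cc32)c1`. It is made from compound 3 by one change: 3-methoxyphenyl in place of hydrogen on an amide-type nitrogen in a ring. This swaps the amide hydrogen for a 3-methoxyphenyl group.

The measured data offer little guidance on this change. Among the compounds with values here, the only measured step, a step that the two limits leave unreadable from compound 1 to compound 2, replaces that same 3-methoxyphenyl group with cyclohexyl, and its size cannot be read. Compound 1 does carry the 3-methoxyphenyl group, but its core differs from that of compound 4. Compound 1 reaches only the limit of > 40000 nM. This gives a weak hint towards higher numbers, meaning weaker inhibition, but no measured size for the step.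

No large change is therefore expected, only a slight lean towards weaker inhibition. The expected size is a 1.6-fold higher number from compound 3 to compound 4 (0.21 log units; within the scatter). The estimate for compound 4 is 30000 nM, with an expected range of 9000 nM to 60000 nM.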

Compound 4, half-maximal inhibitory concentration: > 40000 nM
Compound 4 ended at the assay's limit (the forecaster's own chance of this, stated with the estimate: 40%); at least 1.3-fold (0.12 log units) between middle value and limit.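

Going by these compounds alone, replacing the amide hydrogen of compound 3 with 3-methoxyphenyl gives the first step at this position that can be read in this assay: an at least 2.1-fold higher number from compound 3 to compound 4 (0.33 log units; beyond the scatter). Compound 4 gives > 40000 nM, which is a limit and not a number, so this step gives only the smallest size the change can have, and the true size may be larger. The earlier step at this nitrogen, from compound 1 to compound 2, cannot be read, so this is the first direct sign that 3-methoxyphenyl on this nitrogen gives weaker inhibition than the amide hydrogen, and the limit now holds most of the set: the limit of > 40000 nM in this assay, at which 3 of the 4 values shown sit.

Compound 1, compound 2 and compound 4 all sit at this limit and cannot be ranked against one another, so the shown data do not tell how far inhibition falls with a group on this nitrogen. As far as these compounds go, it also remains open whether the loss belongs to 3-methoxyphenyl itself or would also appear with a methyl group or a short chain ending in an amine on the same nitrogen.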